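The source may report more compounds than this note shows. Statements on the series, on what has been measured and on what is new or still open speak of the compounds shown alone.

In a functional assay on PC-3 cells (Homo sapiens) for inhibition, with a stated time of 72 h (on this read-out higher numbers stand for weaker inhibition and lower numbers for stronger inhibition), three compounds of one series have been examined. Compound 1 `Cc1cc(Cl)ccc1NC(=O)Nc1nc(Sc2c[nH]c3ccccc23)cc(N2CCN(Cc3ccccc3)CC2)n1` gives 22500 nM, the highest of the three numbers, though its separations from the other two lie within the usual scatter. Compound 2 `O=C(Nc1ccccc1)Nc1nc(NC2CC2)cc(Sc2c[nH]c3ccccc23)n1` gives 17500 nM and compound 3 `Cc1ccc(NC(=O)Nc2nc(Nc3ccccc3)cc(Sc3c[nH]c4ccccc34)n2)cc1` gives 18500 nM in this assay, so all three stand at the same level as far as the measurements can tell. Within the data shown here, no pair among them differs in only one place, so no single step can be read from the measured set.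

Compound 4 `COc1ccc(NC(=O)Nc2nc(Sc3c[nH]c4ccccc34)cc(N3CCN(Cc4ccccc4)CC3)n2)cc1` is compound 1 with 4-methoxyphenyl in place of 4-chloro-2-methylphenyl on an amide-type nitrogen. Nothing in the measured compounds tells how this assay answers such a change, and the three values show no spread beyond the scatter across compounds that differ in several places. The expected step is a 1.1-fold lower number from compound 1 to compound 4 (0.05 log units; within the scatter), which is estimated to stay within the scatter, in either direction. The estimate for compound 4 is 20000 nM, with a range from 8000 nM to 50000 nM.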

Compound 4, half-maximal inhibitory concentration: 16700 nM
The estimate for compound 4 lay 1.2-fold (0.08 log units) above the measured number; low and high end bracket the measured number.
By their numbers in this assay, from the lowest: compounds 4, 2, 3 and 1 (each within the scatter of the next).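

In this assay, among these compounds, the exchange of 4-chloro-2-methylphenyl for 4-methoxyphenyl on the amide-type nitrogen gives a 1.3-fold lower number from compound 1 to compound 4 (0.13 log units; within the scatter), the first step that can be read from a single place. At this position, then, one aromatic group of equal heavy-atom count replaces the other, with a methoxy oxygen and a hydrogen-bond acceptor entering and the chlorine leaving, and the number does not move beyond the scatter. Nothing available accounts for this result.

Going by these compounds, whether a carboxylic acid, an amine or a longer chain in place of 4-methoxyphenyl on this nitrogen would move the number beyond the scatter remains open. Among the compounds shown here, also open is how the rest of compound 1 answers change: compound 2 and compound 3 differ from it in several places and offer no single step.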